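This account rests on a few compounds, and the source may have more. Where it says the series, first, only, none or still open, it means among the compounds named here.

Measured in an in vivo functional assay on the whole organism for inhibition, with Rattus norvegicus as the target; on this read-out lower numbers stand for an effect already at smaller amounts and higher numbers for an effect only at larger amounts of compound:
- compound 1 `CCCCc1nc(C)c(CC(=O)N(CC)CC)c(=O)n1Cc1ccc(-c2ccccc2-c2nnn[nH]2)cc1`: 0.089 mg/kg
- compound 2 `CCCCc1nc(C)c(CC(=O)N2CCCC2)c(=O)n1Cc1ccc(-c2ccccc2-c2nnn[nH]2)cc1`: 0.056 mg/kg
- compound 3 `CCCCc1nc(C)c(CC(=O)N2CCN(C)CC2)c(=O)n1Cc1ccc(-c2ccccc2-c2nnn[nH]2)cc1`: "not determined" (no result reported)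

Compound 3 has no number in this assay, so it offers no starting value. Compound 4 `CCCCc1nc(C)c(CCC(=O)N2CCSCC2)c(=O)n1Cc1ccc(-c2ccccc2-c2nnn[nH]2)cc1` differs from it by ((thiomorpholin-4-yl)carbonyl)methyl in place of (4-methylpiperazin-1-yl)carbonyl on a saturated chain carbon bound to an aromatic carbon. Within the data shown here, only one measured step bears on this, a 1.6-fold lower number from compound 1 to compound 2 (0.20 log units; within the scatter), and it concerns a different swap on the carbonyl carbon. No size or direction can therefore be expected for the step from compound 3. The expectation is instead a value close to those of compound 1 and compound 2, with a wide margin. For compound 4, the estimate is 0.12 mg/kg, with an expected range from 0.03 mg/kg to 0.5 mg/kg.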

Compound 4, dose for half-maximal effect: 0.204 mg/kg
Beside the measured number, compound 4's estimate is 1.7-fold (0.23 log units) below it, within the range that was stated.
By their numbers in this assay, from the lowest: compounds 2 and 1 (each within the scatter of the next); then compound 4.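

In this assay, moving to the ((thiomorpholin-4-yl)carbonyl)methyl group gives a 3.6-fold higher number from compound 2 to compound 4 (0.56 log units; beyond the scatter) and a 2.3-fold higher number from compound 1 to compound 4 (0.36 log units; beyond the scatter), the first shifts here beyond the scatter. Unlike the swap between compound 1 and compound 2, this change replaces the amine and lengthens the chain together, so the two contributions cannot be separated. Nothing available explains the shift. Still open, from the compounds shown here alone, is how a pyrrolidin-1-yl amide would read on the longer chain of compound 4, and a thiomorpholin-4-yl amide on the shorter chain of compound 1. Going by these compounds, a morpholin-4-yl amide on either chain is equally open.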